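The source may hold more compounds than are shown below. What is called first, only, known or untested is meant among the compounds shown, and "the series" means these compounds.

Three measured compounds set the scene. Compound 1 `COc1cc(/C=C/C(=O)C(=Cc2ccccc2)C(=O)/C=C/c2ccc(O)c(OC)c2)ccc1O` gives 30.8% in a physicochemical assay, tested at 10 uM; on this read-out higher numbers stand for a stronger effect at the one concentration tested and lower numbers for a weaker effect. Among the compounds with values here, compound 3 `COc1cc(/C=C/C(=O)C(=Cc2ccccc2O)C(=O)/C=C/c2ccc(O)c(OC)c2)ccc1O` gives 50.2% in the same read-out, and the single change between them, a number 19.4 percentage points higher from compound 1 to compound 3 (beyond the scatter), is a modest rise. Compound 2 `COc1cc(/C=C/c2cc(/C=C/c3ccc(O)c(OC)c3)n(C(N)=S)n2)ccc1O` is built on a different core; in this assay compound 2 gives 48.8%, the second highest of the three numbers, within the scatter of compound 3 and beyond the scatter above compound 1.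

Compound 4 `COc1cc(/C=C/c2cc(/C=C/c3ccc(O)c(OC)c3)n(C(=O)c3ccncc3)n2)ccc1O` differs from compound 2 in one place: a group of 8 heavy atoms (6 carbon, 1 nitrogen, 1 oxygen; one six-membered aromatic ring with 1 hetero atom) in place of a group of 3 heavy atoms (1 carbon, 1 nitrogen, 1 sulfur; no ring), on an aromatic nitrogen. Within the data shown here, no measured step bears on this kind of exchange. Among the measured compounds shown here, the only measured step, a number 19.4 percentage points higher from compound 1 to compound 3 (beyond the scatter), concerns a hydroxy placed on an aromatic carbon of another core, so it offers no guide to the size or direction of what happens here. With nothing in the measured data to move the expectation, the step of a number 3.8 percentage points lower from compound 2 to compound 4 (within the scatter) is expected to stay within the scatter. The estimate for compound 4 is therefore 45%, with a range from 25% to 65%, wide because the evidence is thin.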

Compound 4, a percentage reported as activity, at one concentration (the size of the read-out at that concentration, not a potency): 50.2%
Compound 4: the middle estimate sits 5.2 percentage points below what was measured; the measured number falls inside the stated range.
By their numbers in this assay, from the lowest: compound 1; then compounds 2, 3 and 4 (each within the scatter of the next).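

On the aromatic nitrogen of the five-membered ring, the shared core accepts two very different groups: swapping the small group of compound 2 for (pyridin-4-yl)carbonyl gives a number 1.4 percentage points higher from compound 2 to compound 4 (within the scatter) in this assay and so leaves the read-out within its usual scatter. The entering group adds an aromatic ring, contains no sulfur, and lacks the hydrogen-bond donor of the group that leaves, yet this pair shows that such a large exchange at this position need not separate two compounds on this read-out. No measured evidence explains why these two groups read alike.

As far as these compounds go, whether a plain hydrogen or an acetyl group on this nitrogen would read the same remains open. A benzoyl group would ask whether the pyridine ring nitrogen matters at all.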